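The source may report more compounds than this note shows. Statements on the series, on what has been measured and on what is new or still open speak of the compounds shown alone.

Measured compounds in this series:
- compound 1 `COC(C)c1c(NC(=O)Nc2cnc(-n3nccn3)c(Cl)c2)cnc2ccc(F)cc12`: 270 nM
- compound 2 `COC(C)(C)c1c(NC(=O)Nc2cnc(-n3nccn3)c(Cl)c2)cnc2ccc(F)cc12`: 410 nM
- compound 3 `COC(C)c1c(NC(=O)Nc2cnc(-n3nccn3)c(Cl)c2)cnc2sc(C)nc12`: 730 nM

All three values come from a functional assay on OCI-Ly3 cells (Homo sapiens) for antiproliferative activity; on this read-out higher numbers stand for an effect only at larger amounts of compound and lower numbers for an effect already at smaller amounts. Compound 2 differs from compound 1 by methyl in place of hydrogen on a saturated chain carbon bound to an aromatic carbon, an oxygen on a saturated carbon and a saturated chain carbon, and the step of a 1.5-fold higher number from compound 1 to compound 2 (0.18 log units; within the scatter). Compound 3 carries a different core from compound 1; the difference between the two cores is not broken down here. Its value is the highest of the three, yet only the gap to compound 1 is reported as beyond the scatter.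

Compound 4 `CCOC(C)c1c(NC(=O)Nc2cnc(-n3nccn3)c(Cl)c2)cnc2sc(C)nc12` has not been measured. It differs from compound 3 by methyl in place of hydrogen on a saturated chain carbon bound to an oxygen on a saturated carbon. For the measured compounds named here, this is the same kind of change as the one from compound 1 to compound 2, but not the same: there the saturated chain carbon is bound to an aromatic carbon, an oxygen on a saturated carbon and a saturated chain carbon, whereas here it is bound only to an oxygen on a saturated carbon. The expectation for compound 4 rests on the step of a 1.5-fold higher number from compound 1 to compound 2 (0.18 log units; within the scatter) and is a step of a 1.3-fold higher number from compound 3 to compound 4 (0.11 log units; within the scatter). Compound 4 is thus estimated at 950 nM, with a likely range from 400 nM to 2300 nM.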

Compound 4, half-maximal effective concentration: 360 nM
Compound 4: the middle estimate sits 2.6-fold (0.42 log units) above what was measured; measured number outside the range, below it.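

In this assay, going from methoxy to ethoxy on the core of compound 3 gives a 2.0-fold lower number from compound 3 to compound 4 (0.31 log units; beyond the scatter) and does not match the earlier methyl step on the core of compound 1: the same change on two cores in this assay, a 1.5-fold higher number (0.18 log units; within the scatter) from compound 1 to compound 2 and a 2.0-fold lower number (0.31 log units; beyond the scatter) from compound 3 to compound 4, 3.1-fold (0.49 log units) apart, beyond the scatter of two such steps

A methyl step read on one core therefore cannot be carried to the other as a fixed size in this series. For the compounds shown here, this does not show that the core alone sets the outcome: the place differs as well, with the methyl in compound 4 on a saturated chain carbon bound to an oxygen on a saturated carbon, and in compound 2 on a carbon also bound to an aromatic carbon, and each core offers only one pair.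

Still open, going by these compounds, is how 1-ethoxyethyl behaves on the core of compound 1, a comparison that would separate core from place. Also open, on these data alone, is whether a longer chain such as propoxy, or an amine in place of the ether oxygen, would follow compound 4 on the core of compound 3.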